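Notes on a chain-length step, compound 3 to compound 4

The source may hold more compounds than are shown below. What is called first, only, known or untested is meant among the compounds shown, and "the series" means these compounds.

compound 1 `COc1cc2ccc(=O)oc2cc1OCCOc1no[n+]([O-])c1S(=O)(=O)c1ccccc1`: 3540 nM
compound 2 `COc1cc2ccc(=O)oc2cc1OCCCCOc1no[n+]([O-])c1S(=O)(=O)c1ccccc1`: 3040 nM
compound 3 `COc1cc2ccc(=O)oc2cc1OCCCCCOc1c[n+]([O-])on1`: 3850 nM

All three numbers come from a functional assay on MCF7 cells (Homo sapiens) for inhibition, read by MTT assay, with a stated time of 48 h; a higher number here means a weaker inhibitor, a lower number a stronger inhibitor. In it compound 1 gives 3540 nM, compound 2 gives 3040 nM and compound 3 gives 3850 nM; the gaps among the three lie within the usual scatter, so compound 3 cannot be told apart from compound 1 or compound 2 on these numbers. Compound 4 `COc1cc2ccc(=O)oc2cc1OCCCCCCOc1c[n+]([O-])on1` is not yet measured. Against compound 3 it carries a group of 8 heavy atoms (3 carbon, 2 nitrogen, 3 oxygen; one five-membered aromatic ring with 3 hetero atoms) in place of a group of 7 heavy atoms (2 carbon, 2 nitrogen, 3 oxygen; one five-membered aromatic ring with 3 hetero atoms), on a saturated chain carbon, five bonds along the chain from an oxygen on an aromatic ring. Among the measured compounds shown here, no single-change step between measured compounds has been computed here. Compound 1 and compound 2, which also differ in the length of the chain, give numbers within scatter of each other. The expected step is a 1.0-fold lower number from compound 3 to compound 4 (0.01 log units; within the scatter), nothing beyond the scatter in either direction. Compound 4 is estimated at 3800 nM in this assay, with a range of 2000 nM to 7500 nM.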

Compound 4, half-maximal inhibitory concentration: 4480 nM
Compound 4: the middle estimate sits 1.2-fold (0.07 log units) below what was measured; the range from low to high includes it.
By their numbers in this assay, from the lowest: compounds 2, 1, 3 and 4 (each within the scatter of the next).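

In this assay the series now has its first single-change step, a 1.2-fold higher number from compound 3 to compound 4 (0.07 log units; within the scatter), so at this saturated chain carbon, swapping the group of 7 heavy atoms for the group of 8 heavy atoms gives no change that can be told from scatter. No supporting data bear on this result. The compounds shown leave open whether a longer chain would give a step beyond the scatter. Also open, on these data alone, is how a carboxylic acid or an amine in place of the five-membered aromatic ring would read at this position.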